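The source may report more compounds than this note shows. Statements on the series, on what has been measured and on what is new or still open speak of the compounds shown alone.

Compound 1 `O=C(Nc1ccc(-c2cnc3ccccn23)cc1)c1ccc([N+](=O)[O-])o1` gives 360 nM in a functional assay on AGS cells (Homo sapiens) for antiproliferative activity, read by CCK-8 assay, with a stated time of 72 h; a lower number here means a stronger inhibitor, a higher number a weaker inhibitor.
Compound 2 `COc1ccn2c(-c3ccc(NC(=O)c4ccc([N+](=O)[O-])o4)c(C)c3)cnc2c1` gives 430 nM in this assay.

Among the compounds with values here, of the two numbers in hand, the one for compound 2 is the larger, yet the gap to compound 1 lies within the usual scatter of this assay, so the two compounds cannot be told apart on these data. Compound 3 `Cc1cc(-c2cnc3ccccn23)ccc1NC(=O)c1ccc([N+](=O)[O-])o1` is compound 2 with one change: hydrogen in place of methoxy on an aromatic carbon. Within the data shown here, no measured pair isolates this change. What the data do show is that compound 1, which carries neither the methoxy nor the methyl of compound 2, returns a number within the scatter of compound 2, so the substitution on the shared core has so far moved this assay little. The step of a 1.1-fold lower number from compound 2 to compound 3 (0.03 log units; within the scatter) is therefore expected to stay within the scatter, in no particular direction. Compound 3 is expected to give about 400 nM in this assay, within a range of 200 nM to 800 nM.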

Compound 3, half-maximal inhibitory concentration: 730 nM
For compound 3 the middle estimate is 1.8-fold (0.26 log units) below the measured one; the measured number falls inside the stated range.
By their numbers in this assay, from the lowest: compounds 1, 2 and 3 (each within the scatter of the next, the first and the last beyond it).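

In this assay, the methoxy on the aromatic carbon of the six-membered aromatic ring with 1 nitrogen can now be read on its own: hydrogen in its place gives a 1.7-fold higher number from compound 2 to compound 3 (0.23 log units; within the scatter) and so leaves no measurable effect of this change. Within the data shown here, the methyl can also be read alone for the first time, since methyl in place of hydrogen on an aromatic carbon gives a 2.0-fold higher number from compound 1 to compound 3 (0.31 log units; beyond the scatter) and this modest step is the only one here beyond the scatter. Nothing on hand accounts for either step.

The compounds shown leave open whether an amine or a longer chain such as ethoxy at the methoxy position would move the number beyond the scatter. They also leave open whether the methyl step holds when the methoxy is present.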